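Pyridinyl Urea Isomers and Mouse Microsomal Clearance

This account rests on a few compounds, and the source may have more. Where it says the series, first, only, none or still open, it means among the compounds named here.

Compound 1 `O=C(Nc1ccc(F)c(C(F)(F)F)c1)Nc1ccccn1` gives 705 uL/min in an ADME assay on microsomes from liver (Mus musculus) for metabolic stability, using NADPH, with a stated time of 60 min; on this read-out lower numbers stand for slow clearance and higher numbers for fast clearance. For the measured compounds named here, compound 2 `O=C(Nc1cccnc1)Nc1ccc(F)c(C(F)(F)F)c1` gives 154 uL/min in this assay, the lowest of the two numbers, and the only measured step, a 4.6-fold lower number from compound 1 to compound 2 (0.66 log units; beyond the scatter), is the exchange of pyridin-2-yl for pyridin-3-yl. Compound 3 `O=C(Nc1ccncc1)Nc1ccc(F)c(C(F)(F)F)c1` carries the change (pyridin-4-yl in place of pyridin-3-yl on an amide-type nitrogen). Going by the values given here, no measured step involves pyridin-4-yl, so the earlier step shows only that exchanging one pyridinyl isomer for another can move the number, not which way. Compound 3 is therefore expected to give 200 uL/min, with a range from 70 uL/min to 600 uL/min. The expected step of a 1.3-fold higher number from compound 2 to compound 3 (0.11 log units; within the scatter) is estimated to lie within the scatter.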

Compound 3, intrinsic clearance in a liver preparation (reported as CLH), per the amount of preparation that the assay uses in the Mus musculus assay: 37 uL/min
Compound 3: middle estimate off by 5.4-fold (0.73 log units), on the high side, and the stated range ends above it.
By their numbers in the Mus musculus assay, from the lowest: compound 3; then compound 2; then compound 1.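

In the Mus musculus assay pyridin-4-yl in place of pyridin-3-yl gives a 4.2-fold lower number from compound 2 to compound 3 (0.62 log units; beyond the scatter) and in place of pyridin-2-yl gives a 19-fold lower number from compound 1 to compound 3 (1.28 log units; beyond the scatter) among these three isomers, so the lowest clearance number belongs to pyridin-4-yl. In a physicochemical assay for solubility, read by nephelometry, measured as kinetic solubility, at pH 2 (a lower number here means a less soluble compound, a higher number a more soluble compound), compound 2 gives 50 ug/mL and compound 3 gives 6.3 ug/mL at the same amide-type nitrogen. The lower clearance number thus comes with lower solubility: (the measured solubility of compound 2, 50 ug/mL, and of compound 3, 6.3 ug/mL, a 7.9-fold lower number (0.90 log units; beyond the scatter)).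

Going by these compounds, how the two read-outs move apart stays open. The compounds shown do not tell how a morpholine or a carboxylic acid on the pyridin-4-yl ring would read in either assay.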